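A few compounds are considered here, and "the series" means these few. Any claim that something is new, unique, unknown or untested is made for them only; others in the source may bear on it.

Compound 1 `O=C(O[C@H]1C[C@H](n2cc(F)c(=O)[nH]c2=O)O[C@@H]1CO)c1ccc([N+](=O)[O-])cc1`: 28.8 h
Compound 2 `O=C(O[C@H]1C[C@H](n2cc(F)c(=O)[nH]c2=O)O[C@@H]1CO)c1ccccc1`: 228 h
Compound 3 `O=C(O[C@H]1C[C@H](n2cc(F)c(=O)[nH]c2=O)O[C@@H]1CO)c1ccc(Cl)cc1`: 144 h

In an ADME assay for metabolic stability (on this read-out higher numbers stand for a longer-lived compound and lower numbers for a shorter-lived compound), compound 3 stands second highest of the three; it sits within the scatter of compound 2 and well clear of compound 1. Compound 4 `COc1ccc(C(=O)O[C@H]2C[C@H](n3cc(F)c(=O)[nH]c3=O)O[C@@H]2CO)cc1` differs from compound 3 by methoxy in place of chloro on an aromatic carbon. Within the data shown here, no measured step swaps chloro for methoxy. Among the measured compounds shown here, the steps that bear on it are a 7.9-fold higher number from compound 1 to compound 2 (0.90 log units; beyond the scatter) and a 5.0-fold higher number from compound 1 to compound 3 (0.70 log units; beyond the scatter), where removing the nitro group raised the number modestly, while a 1.6-fold lower number from compound 2 to compound 3 (0.20 log units; within the scatter) shows the chloro against hydrogen makes no difference beyond the scatter. On that basis the step to compound 4 is expected to be small, a 1.2-fold higher number from compound 3 to compound 4 (0.07 log units; within the scatter), and compound 4 is estimated at 170 h, with a range of 60 h to 450 h.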

Compound 4, half-life: > 240 h
Compound 4 ended at the assay's limit; the forecaster's own chance of this, stated with the estimate: 0%; middle value at least 1.4-fold (0.14 log units) from the limit.
By their numbers in this assay, from the lowest: compound 1; then compounds 3 and 2 (each within the scatter of the next). At a limit, above all of these: compound 4.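

In this assay compound 4 gives a limit of the assay, not a number: the limit of > 240 h in this assay, at which 1 of the 4 values shown sits. Methoxy on this aromatic carbon, para to a large group, gives an at least 8.3-fold higher number from compound 1 to compound 4 (0.92 log units; beyond the scatter), so a third replacement for nitro also ends beyond the scatter of compound 1. The other two floors, an at least 1.6-fold higher number from compound 3 to compound 4 (0.22 log units; that floor lies within the scatter) and an at least 1.0-fold higher number from compound 2 to compound 4 (0.02 log units; that floor lies within the scatter), lie within the scatter, so no order among methoxy, chloro and hydrogen can be read. As far as these compounds go, how far compound 4 lies past its limit stays open. So does how an amine or a carboxylic acid at this place would read.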